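Swapping methyl for chloro at a ring position

This account rests on a few compounds, and the source may have more. Where it says the series, first, only, none or still open, it means among the compounds named here.

Measured so far in an assay on IMR-32 cells with Neuronal acetylcholine receptor; alpha4/beta2 (Homo sapiens) as the target; on this read-out higher numbers stand for larger maximal responses and lower numbers for smaller maximal responses:
compound 1 `Cc1cncc(OC[C@@H]2CCCN2C)c1` gives 78.8%
compound 2 `CCCc1cncc(OC[C@@H]2CCCN2C)c1` gives 2.5%
compound 3 `Cc1ccc(OC[C@@H]2CCCN2C)cn1` gives 30.9%

Compound 3 stands second highest of the three; compound 1 sits clearly above it and compound 2 clearly below it. Compound 4 `CN1CCC[C@H]1COc1ccc(Cl)nc1` differs from compound 3 by chloro in place of methyl on an aromatic carbon, the change sitting next to the ring nitrogen. For the measured compounds named here, the only measured step, a number 76.3 percentage points lower from compound 1 to compound 2 (beyond the scatter), concerns a larger group added on a saturated chain carbon of a different core and does not speak to a chloro-for-methyl swap of equal size. Going by the values given here, no step in these data bears directly on compound 4, so the expected step of a number 14.1 percentage points higher from compound 3 to compound 4 (beyond the scatter) is a modest one, tilted slightly upward but with wide uncertainty. Compound 4 is therefore estimated at 45%, within the range 15% to 80%.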

Compound 4, largest response reached (reported as maximum), in percent of the reference or control that the assay uses: 17.9%
The estimate for compound 4 lay 27.1 percentage points above the measured number, within the range that was stated.
By their numbers in this assay, from the lowest: compound 2; then compound 4; then compound 3; then compound 1.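

On an aromatic carbon next to the ring nitrogen, chloro in place of methyl gives a number 13 percentage points lower from compound 3 to compound 4 (beyond the scatter) in this assay. So an exchange of one heavy atom for one heavy atom at this position is enough to change the maximal response, here downward. Nothing measured here accounts for that fall. For the compounds shown here, with only two groups compared at this position, it remains open how an amine, a methoxy group or a longer chain would behave there. From the compounds shown here alone, whether chloro in place of methyl has a similar result on the core of compound 1 also remains open.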